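The source may hold more compounds than are shown below. What is called first, only, known or untested is meant among the compounds shown, and "the series" means these compounds.

Measured so far:
Compound 1 `CCCC/C(=C(/c1ccc(/C=C/C(=O)O)cc1)c1ccc2[nH]ncc2c1)c1ccccc1`: 10 nM
Compound 2 `O=C(O)/C=C/c1ccc(/C(=C(\c2ccccc2)C(F)(F)F)c2ccc3[nH]ncc3c2)cc1`: 5.5 nM

Both numbers come from a functional assay on MCF7 cells (Homo sapiens) for cytotoxicity, read by CellTiter-Glo, with a stated time of 5 days; a higher number here means a weaker inhibitor, a lower number a stronger inhibitor. Compound 2 has the lower of the two numbers, and its nearest neighbour is compound 1, but the two differ only by a 1.8-fold lower number from compound 1 to compound 2 (0.26 log units; within the scatter), so the data do not separate them. Within the data shown here, that single step is also the only one that bears on compound 3 `O=C(O)/C=C/c1ccc(/C(=C(\c2ccccc2)C2CCC2)c2ccc3[nH]ncc3c2)cc1`, which differs from compound 2 by cyclobutyl in place of trifluoromethyl on a double-bonded chain carbon bound to an aromatic carbon and a double-bonded chain carbon. Because the step of a 1.8-fold lower number from compound 1 to compound 2 (0.26 log units; within the scatter) shows that exchanging one group for another at this place of the shared core left the number essentially unchanged, another group entering at the same place is expected to do much the same, and no step beyond the scatter is expected in this assay in either direction. For compound 3, the expected step is a 1.5-fold higher number from compound 2 to compound 3 (0.16 log units; within the scatter). In this assay compound 3 is therefore estimated at 8 nM, with a range from 3 nM to 25 nM that allows for the ordinary spread of repeated measurements.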

Compound 3, half-maximal inhibitory concentration: 1.4 nM
Beside the measured number, compound 3's estimate is 5.7-fold (0.76 log units) above it, outside the stated range (below it).
By their numbers in this assay, from the lowest: compound 3; then compounds 2 and 1 (each within the scatter of the next).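

In this assay, the group on a double-bonded chain carbon bound to an aromatic carbon and a double-bonded chain carbon can shift the number after all: cyclobutyl in place of trifluoromethyl gives a 3.9-fold lower number from compound 2 to compound 3 (0.59 log units; beyond the scatter), and cyclobutyl in place of butyl gives a 7.1-fold lower number from compound 1 to compound 3 (0.85 log units; beyond the scatter), whereas the earlier exchange of butyl for trifluoromethyl gave only a 1.8-fold lower number from compound 1 to compound 2 (0.26 log units; within the scatter). Both new steps are modest, but they show that this place is not indifferent to what it carries, and that the trifluoromethyl and cyclobutyl groups, at 4 heavy atoms each, can differ here even with the same heavy-atom count. Nothing available explains why cyclobutyl gives the lowest of the three numbers.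

With only one ring-bearing group at this place, the compounds shown leave open whether the ring itself matters or whether this is particular to cyclobutyl. Cyclopropyl or cyclopentyl would test ring size, an open-chain isopropyl would test the need for a ring, and an amine or a hydroxyl group would show how a group of a quite different kind fares at the same place.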